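From 2-Methoxyphenyl to 3-Chlorophenyl at the Limit

The source may report more compounds than this note shows. Statements on the series, on what has been measured and on what is new or still open speak of the compounds shown alone.

In a functional assay on HCT-116 cells (Homo sapiens) for antiproliferative activity, with a stated time of 72 h (on this read-out higher numbers stand for weaker inhibition and lower numbers for stronger inhibition), compound 1 `COc1ccccc1/C=C/c1nc(Nc2ccc(O)cc2)c2ccccc2n1` reads > 25000 nM; this is a limit of the assay and not a number. In this assay compound 2 `COc1ccccc1/C=C/c1nc(Nc2cccc(O)c2)c2ccccc2n1` gives 21700 nM and that step (an at least 1.1-fold lower number from compound 1 to compound 2 (0.06 log units; that floor lies within the scatter)) stays within the scatter. Compound 3 `Oc1ccc(Nc2nc(/C=C/c3cccc(Cl)c3)nc3ccccc23)cc1` differs elsewhere (3-chlorophenyl in place of 2-methoxyphenyl on a double-bonded chain carbon bound to a double-bonded chain carbon): 3-chlorophenyl in place of 2-methoxyphenyl on a double-bonded chain carbon bound to a double-bonded chain carbon. Going by the values given here, the one measured step changes another place, so it gives no size for this change, and compound 1 remains at the limit of > 25000 nM in this assay, at which 1 of the 2 values shown sits. A small step toward lower numbers is therefore expected in this assay (an at least 1.6-fold lower number from compound 1 to compound 3 (0.22 log units; that floor lies within the scatter)). Compound 3 is estimated at 15000 nM (range 5000 nM to 25000 nM).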

Compound 3, half-maximal inhibitory concentration: 21900 nM
The estimate for compound 3 lay 1.5-fold (0.16 log units) below the measured number; measured number inside the range.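

Placing 3-chlorophenyl in place of 2-methoxyphenyl on a double-bonded chain carbon bound to a double-bonded chain carbon gives, in this assay, an at least 1.1-fold lower number from compound 1 to compound 3 (0.05 log units; that floor lies within the scatter), so this position shows no change beyond the scatter. Compound 3 gives a measured number, but compound 1 reads > 25000 nM, which is a limit of the assay and not a number. The true size of this step therefore stays unknown: the limit of > 25000 nM in this assay, at which 1 of the 3 values shown sits.

From the compounds shown here alone, whether an amine or a carboxylic acid on the ring at this position would move the number beyond the scatter stays open.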